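Adding three methoxy groups to a stilbene acid

The compounds below may be only part of what the source reports. "The series", "measured", "known", "first", "only" and "open" are said of these compounds alone.

Measured so far:
compound 1 `COc1cccc(/C(=C\c2cn(C(C)=O)c3ccc(OCc4ccccc4)cc23)C(=O)O)c1`, 45200 nM
compound 2 `CC(=O)n1cc(/C=C(/C(=O)O)c2ccccc2)c2cc(OCc3ccccc3)ccc21`, 57500 nM
compound 3 `COc1ccc(/C(=C\c2c[nH]c3ccc(OCc4ccccc4)cc23)C(=O)O)cc1`, "not determined" (no result reported)

In a functional assay on A549 cells (Homo sapiens) for cytotoxicity, read by MTT assay, with a stated time of 72 h (on this read-out lower numbers stand for stronger inhibition and higher numbers for weaker inhibition), compound 2 gives the highest of the two numbers; its nearest neighbour is compound 1, and the step of a 1.3-fold higher number from compound 1 to compound 2 (0.10 log units; within the scatter) is within the scatter. Compound 4 `COc1cc(/C(=C\c2cn(C(C)=O)c3ccc(OCc4ccccc4)cc23)C(=O)O)cc(OC)c1OC` differs from compound 2 by 3,4,5-trimethoxyphenyl in place of phenyl on a double-bonded chain carbon bound to a carbonyl carbon and a double-bonded chain carbon. Going by the values given here, the only measured step, hydrogen for methoxy on the aromatic ring, left the read-out essentially unchanged, so a shift of modest size is expected, and its direction is uncertain. Compound 4 is estimated at 30000 nM (range 5000 nM to 150000 nM), an expected step of a 1.9-fold lower number from compound 2 to compound 4 (0.28 log units; within the scatter) in this assay.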

Compound 4, half-maximal inhibitory concentration: 89100 nM
Compound 4: the middle estimate sits 3.0-fold (0.47 log units) below what was measured, and the stated range covers the measured number.
By their numbers in this assay, from the lowest: compounds 1, 2 and 4 (each within the scatter of the next).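

In this assay, 3,4,5-trimethoxyphenyl in place of phenyl gives a 1.5-fold higher number from compound 2 to compound 4 (0.19 log units; within the scatter) and in place of 3-methoxyphenyl gives a 2.0-fold higher number from compound 1 to compound 4 (0.29 log units; within the scatter) at the same carbon. Both steps lie within the scatter, so even with the largest group shown at this position, the read-out does not separate the three aryl groups, and all three compounds stay in the same range. Nothing at hand bears on this result. From the compounds shown here alone, whether an amine or a hydroxyl group on the phenyl at this carbon would give a step beyond the scatter remains open.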